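Swapping one hydroxyphenyl arm in a pyridine-free shared core

The source may hold more compounds than are shown below. What is called first, only, known or untested is meant among the compounds shown, and "the series" means these compounds.

Compound 2 `Oc1cccc(-c2cc(-c3ccccc3OC(F)(F)F)cc(-c3cccc(O)c3)n2)c1` holds the lowest of the two numbers recorded in a functional assay on HCT-15 cells (Homo sapiens) for inhibition (on this read-out higher numbers stand for weaker inhibition and lower numbers for stronger inhibition), where compound 2 gives 4220 nM. Compound 1 `Oc1ccc(-c2cc(-c3ccccc3OC(F)(F)F)cc(-c3ccccc3O)n2)cc1` gives 9820 nM in this assay, a step beyond the scatter. Compound 3 `Oc1ccc(-c2cc(-c3ccccc3OC(F)(F)F)cc(-c3cccc(O)c3)n2)cc1` differs from compound 2 by 4-hydroxyphenyl in place of 3-hydroxyphenyl on an aromatic carbon. Among the measured compounds shown here, no step between measured compounds isolates this single change, but a modest rise is expected because compound 1 gives 9820 nM with two 4-hydroxyphenyl groups. Compound 3 is therefore expected at 6500 nM, within 3000 nM to 14000 nM. This would amount to an expected 1.5-fold higher number from compound 2 to compound 3 (0.19 log units; within the scatter) in this assay.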

Compound 3, half-maximal inhibitory concentration: 2310 nM
For compound 3 the middle estimate is 2.8-fold (0.45 log units) above the measured one; the whole stated range lies above it.
By their numbers in this assay, from the lowest: compounds 3 and 2 (each within the scatter of the next); then compound 1.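

At the aromatic carbon next to the ring nitrogen, 4-hydroxyphenyl and 3-hydroxyphenyl cannot be told apart in this assay, where the swap gives a 1.8-fold lower number from compound 2 to compound 3 (0.26 log units; within the scatter). The change that does register is 3-hydroxyphenyl in place of 2-hydroxyphenyl, with a 4.3-fold lower number from compound 1 to compound 3 (0.63 log units; beyond the scatter), so among these arms only 2-hydroxyphenyl stands apart from compound 3. Nothing available explains either step. Still open, as far as these compounds go, is whether the hydroxyl matters on these arms at all, and how a methoxy group, an amine or a carboxylic acid in its place would read.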